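Series notes: thiophene in place of methoxyphenyl

This account rests on a few compounds, and the source may have more. Where it says the series, first, only, none or still open, it means among the compounds named here.

The shared core carries a variable aryl group; compound 1 `COc1ccc(-c2cn3ccnc3c(-c3ccc4ncn(C5CCCCC5)c4c3)n2)cc1` bears 4-methoxyphenyl and compound 2 `COc1ccccc1-c1cn2ccnc2c(-c2ccc3ncn(C4CCCCC4)c3c2)n1` bears 2-methoxyphenyl. In a functional assay on SN12C cells (Homo sapiens) for inhibition, read by sulforhodamine B assay, with a stated time of 48 h, tested at 10 uM (a lower number here means less inhibition, a higher number more inhibition at the concentration tested (going by the name of the read-out)), compound 1 gives 63.6%, and compound 2 gives 7.73%. Within the data shown here, the single measured step, a number 55.9 percentage points lower from compound 1 to compound 2 (beyond the scatter), shows that moving the methoxy group on the phenyl ring alone shifts the read-out strongly. Among the measured compounds shown here, compound 2 therefore stands lowest of the two numbers, with compound 1 as its only neighbour, well beyond the scatter above it.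

Compound 3 `c1csc(-c2cn3ccnc3c(-c3ccc4ncn(C5CCCCC5)c4c3)n2)c1` is the next variant: thiophen-2-yl in place of 2-methoxyphenyl on an aromatic carbon. For the measured compounds named here, no measured step covers an exchange of the whole aryl ring for a five-membered heteroaryl; the one step on record only bears on it indirectly, by showing that a change at this position can move the number widely, in the case of the methoxy shift a lowering of the size seen in the step from compound 1 to compound 2. On these data alone, both directions from compound 2 remain open, since compound 2 already sits near the bottom of the range.

On this basis the expected value of compound 3 in this assay is 30%, with a range of 0% to 70%, which is the expected step of a number 22.3 percentage points higher from compound 2 to compound 3 (beyond the scatter).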

Compound 3, a percentage reported as inhibition, at one concentration (the size of the read-out at that concentration, not a potency): 2.84%
For compound 3 the middle estimate is 27.2 percentage points above the measured one; low and high end bracket the measured number.
By their numbers in this assay, from the lowest: compounds 3 and 2 (each within the scatter of the next); then compound 1.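

In this assay, thiophen-2-yl in place of 2-methoxyphenyl reads as a number 4.9 percentage points lower from compound 2 to compound 3 (within the scatter), so at this aromatic carbon the five-membered aromatic ring with 1 hetero atom cannot be told apart from 2-methoxyphenyl. Set against 4-methoxyphenyl, the same exchange gives a number 60.8 percentage points lower from compound 1 to compound 3 (beyond the scatter), so the high read-out of compound 1 now stands apart from two different groups, one of which carries no methoxy group at all, and an aromatic ring at this carbon is not enough on its own to keep the number high. No measurement on hand accounts for these differences.

On these data alone, whether the read-out of compound 1 depends on the methoxy group itself or would hold with another substituent in its place stays open; plain phenyl, 4-hydroxyphenyl and 4-(dimethylamino)phenyl would separate these cases. Also open, as far as these compounds go, is whether thiophen-3-yl or a thiophene bearing a methoxy group would read differently from thiophen-2-yl, and all of these numbers are sizes at a single concentration, not potencies.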